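This account rests on a few compounds, and the source may have more. Where it says the series, first, only, none or still open, it means among the compounds named here.

Compound 1 `Cn1c(=O)c(C(=O)Nc2ccc(Oc3ccncc3-c3cccnc3)c(F)c2)nn(-c2ccccc2F)c1=O` gives 2100 nM in a functional assay on HT-29 cells (Homo sapiens) for cytotoxicity, read by MTT assay, with a stated time of 72 h; on this read-out higher numbers stand for weaker inhibition and lower numbers for stronger inhibition.
Compound 2 `Cn1c(=O)c(C(=O)Nc2ccc(Oc3ccncc3-c3cccnc3)c(F)c2)nn(-c2c(Cl)cccc2Cl)c1=O` gives 780 nM in this assay.
Compound 3 `Cn1c(=O)c(C(=O)Nc2ccc(Oc3ccncc3-c3cccnc3)c(F)c2)nn(-c2ccc(F)c(Cl)c2)c1=O` gives 4780 nM in this assay.

Compound 3 has the highest number of the three, so the weakest inhibition: a 2.3-fold higher number from compound 1 to compound 3 (0.36 log units; beyond the scatter) and a 6.1-fold higher number from compound 2 to compound 3 (0.79 log units; beyond the scatter). Compound 4 `COc1ccc(-n2nc(C(=O)Nc3ccc(Oc4ccncc4-c4cccnc4)c(F)c3)c(=O)n(C)c2=O)c(OC)c1` is not yet measured and differs from compound 3 in one place: 2,4-dimethoxyphenyl in place of 3-chloro-4-fluorophenyl on an aromatic nitrogen. The two steps just named bear on this change, since each also swaps the group on that aromatic nitrogen of the shared core, and a 2.7-fold lower number from compound 1 to compound 2 (0.43 log units; beyond the scatter) shows that this position accepts different groups with modest shifts. Another modest move toward a lower number is therefore expected, about a 3.0-fold lower number from compound 3 to compound 4 (0.48 log units; beyond the scatter). Compound 4 is expected to give roughly 1600 nM (range 500 nM to 5000 nM) in this assay.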

Compound 4, half-maximal inhibitory concentration: 890 nM
The estimate for compound 4 lay 1.8-fold (0.25 log units) above the measured number; the measured number falls inside the stated range.
By their numbers in this assay, from the lowest: compounds 2 and 4 (each within the scatter of the next); then compound 1; then compound 3.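

In this assay, this position on the aromatic nitrogen also accepts a group with two methoxy substituents and no halogen (a 5.4-fold lower number from compound 3 to compound 4 (0.73 log units; beyond the scatter); a 2.4-fold lower number from compound 1 to compound 4 (0.37 log units; beyond the scatter)). The 2,4-dimethoxyphenyl group of compound 4 and the 2,6-dichlorophenyl group of compound 2 give matching numbers (a 1.1-fold higher number from compound 2 to compound 4 (0.06 log units; within the scatter)), so halogens are not required for the lowest numbers in this set. No measurement here explains these shifts. Open, going by these compounds, is whether one methoxy group alone would give the same number. Also open, on these data alone, is how a phenyl carrying an amine or a carboxylic acid would behave here.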